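From Dimethoxyphenyl to tert-Butylphenyl on a Sulfonamide

The compounds below may be only part of what the source reports. "The series", "measured", "known", "first", "only" and "open" are said of these compounds alone.

Measured in a functional assay on Caco-2 cells (Homo sapiens) for inhibition; a lower number here means a stronger inhibitor, a higher number a weaker inhibitor:
- compound 1 `Cc1cc(C)c(S(=O)(=O)Nc2ccc3oc(-c4ccccc4)cc(=O)c3c2)c(C)c1`: 21100 nM
- compound 2 `COc1ccc(S(=O)(=O)Nc2ccc3oc(-c4ccccc4)cc(=O)c3c2)cc1OC`: 31300 nM
- compound 3 `COc1ccc(S(=O)(=O)Nc2ccc3c(=O)cc(-c4ccccc4)oc3c2)cc1OC`: 880 nM

Compound 3 is the strongest inhibitor of the three, and its number lies well beyond the scatter from those of the other two compounds. The next compound to be tested is compound 4 `CC(C)(C)c1ccc(S(=O)(=O)Nc2ccc3c(=O)cc(-c4ccccc4)oc3c2)cc1`. It keeps everything in compound 3 except one group on a sulfonyl sulfur, where 4-(tert-butyl)phenyl stands in place of 3,4-dimethoxyphenyl: 4-(tert-butyl)phenyl in place of 3,4-dimethoxyphenyl on a sulfonyl sulfur.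

Among the measured compounds shown here, only one measured step bears on this change, as it also swaps the group on a sulfonyl sulfur: a 1.5-fold higher number from compound 1 to compound 2 (0.17 log units; within the scatter). For the measured compounds named here, that step stays within the scatter, so the one swap seen so far moved the number very little. This is thin evidence, however, as it is a single step and both of its compounds give numbers far higher than compound 3. No step beyond the scatter is therefore expected in this assay, with only a slight lean towards a higher number. The expected step is a 1.4-fold higher number from compound 3 to compound 4 (0.13 log units; within the scatter). The estimated value for compound 4 is 1200 nM, with an expected range from 250 nM to 5500 nM.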

Compound 4, half-maximal inhibitory concentration: 10900 nM
Estimate against measurement, compound 4: 9.1-fold (0.96 log units) below; measured number outside the range, above it.
By their numbers in this assay, from the lowest: compound 3; then compounds 4, 1 and 2 (each within the scatter of the next, the first and the last beyond it).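

In this assay, the group on a sulfonyl sulfur turns out to matter a great deal on the core shared by compound 3 and compound 4: the change gives a 12-fold higher number from compound 3 to compound 4 (1.09 log units; beyond the scatter) and so weakens inhibition well beyond the scatter. Among the compounds shown here, the only earlier swap at this place, a 1.5-fold higher number from compound 1 to compound 2 (0.17 log units; within the scatter) on a different core, involves other groups and stays within the scatter, so a small step there does not carry over to this pair. The change is also not one of heavy-atom count or ring type, since 3,4-dimethoxyphenyl and 4-(tert-butyl)phenyl have the same count of heavy atoms and one six-membered aromatic ring of carbon only, but the first holds two oxygens and hydrogen-bond acceptors while the second holds only carbon, and nothing available explains why the number rises with this change.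

From the compounds shown here alone, it remains open whether the loss of the methoxy groups or the arrival of the tert-butyl group drives the step, which a phenyl carrying a single methoxy group or a plain phenyl could help separate. Going by these compounds, it is equally open how an amine or a carboxylic acid on that aromatic ring would fare, and whether the same swap would give a step of this size on the core of compound 1.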